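The source may report more compounds than this note shows. Statements on the series, on what has been measured and on what is new or still open speak of the compounds shown alone.

Of the compounds shown here, three have been tested so far in a functional assay on DU-145 cells (Homo sapiens) for inhibition, read by trypan blue exclusion, with a stated time of 96 h; a higher number here means a weaker inhibitor of growth, a lower number a stronger inhibitor of growth. Compound 1 `CCOc1ccc(/C=C(/Sc2ccccc2Cl)C(=O)c2ccc(Cl)cc2)cc1OC` gives 50000 nM, the highest of the three numbers, which makes it the weakest growth inhibitor of the group. Compound 3 `Cc1ccc(S/C(=C/c2ccc(Cl)cc2Cl)C(=O)c2ccc(Cl)cc2)cc1` gives 10000 nM, and compound 2 `COc1ccc(S(=O)(=O)/C(=C/c2ccc(Br)cc2)C(=O)c2ccc(Br)cc2)cc1` gives 6000 nM. Both of these values lie beyond the usual scatter from that of compound 1.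

The next compound to be tested is compound 4 `CCOc1ccc(/C=C(/Sc2ccc(C)cc2)C(=O)c2ccc(Cl)cc2)cc1OC`. It keeps the core of compound 1 and changes one group, with 4-methylphenyl in place of 2-chlorophenyl on a sulfur. Among the compounds with values here, no two measured compounds differ in only one place, so there is no direct step to serve as a guide. The nearest hint comes from compound 3, which also carries 4-methylphenyl on a sulfur and gives 10000 nM, although it differs from compound 1 in other places too. That single comparison is weak evidence, so only a modest move towards stronger inhibition seems reasonable. The expected step of a 2.8-fold lower number from compound 1 to compound 4 (0.44 log units; beyond the scatter) is towards a lower number and is estimated to lie slightly beyond the scatter. The estimated value for compound 4 is 18000 nM, with an expected range from 6000 nM to 50000 nM.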

Compound 4, concentration for 50% growth inhibition: 25000 nM
Compound 4: the middle estimate sits 1.4-fold (0.14 log units) below what was measured; the range from low to high includes it.
By their numbers in this assay, from the lowest: compounds 2 and 3 (each within the scatter of the next); then compounds 4 and 1 (each within the scatter of the next).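

Within the data shown here, this is the first direct reading at this place, on a sulfur whose other neighbour is a double-bonded chain carbon. Compound 1 and compound 4 differ only in the group held there. In this assay, putting 4-methylphenyl in place of 2-chlorophenyl gives a 2.0-fold lower number from compound 1 to compound 4 (0.30 log units; within the scatter), so the two groups cannot be told apart in this assay, even though each has a six-membered aromatic ring of carbon only and the same count of heavy atoms. No other measurement bears on this result, so the data offer no explanation for it.

Among these compounds, the single step replaces chlorine with methyl and also changes where the group sits on the ring, so the two parts of the change cannot be separated, and it shows only that this one exchange between two substituted phenyl rings leaves the number within the scatter. Still open, going by these compounds, is whether a group of a different kind on the same sulfur, such as a ring bearing an amine or a carboxylic acid, or a longer carbon chain in place of the ring, would produce a step beyond the scatter.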